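Swapping a hydroxyethyl amide for an acid-bearing branched chain

The source may report more compounds than this note shows. Statements on the series, on what has been measured and on what is new or still open speak of the compounds shown alone.

Measured compounds:
- compound 1, `CCn1c(C(=O)N[C@H](C)C(=O)OC)ccc1C(CC)(CC)c1ccc(OCS(=O)(=O)c2ccccc2)c(C)c1`: > 50000 nM
- compound 2, `CCn1c(C(=O)NCCO)ccc1C(CC)(CC)c1ccc(OCS(=O)(=O)c2ccccc2)c(C)c1`: 15500 nM
- compound 3, `CCn1c(C(=O)NC(C)(C)CO)ccc1C(CC)(CC)c1ccc(OCS(=O)(=O)c2ccccc2)c(C)c1`: 20700 nM

Three compounds share one core and differ only in the group on the amide-type nitrogen. In a functional assay on MCF7 cells (Homo sapiens) for antiproliferative activity, read by MTT assay, with a stated time of 24 h (on this read-out higher numbers stand for weaker inhibition and lower numbers for stronger inhibition), compound 1 gives > 50000 nM, which is a limit of the assay rather than a number. Compound 2 gives 15500 nM and compound 3 gives 20700 nM in this assay; the two lie within the scatter of each other, so compound 2 holds the lowest of the two numbers actually measured, with compound 3 alongside it.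

The new compound 4, `CCn1c(C(=O)N[C@H](C(=O)O)C(C)C)ccc1C(CC)(CC)c1ccc(OCS(=O)(=O)c2ccccc2)c(C)c1`, changes the same position: 1-carboxy-2-methylpropyl in place of 2-hydroxyethyl on an amide-type nitrogen. The measured step that bears on this is an at least 3.2-fold lower number from compound 1 to compound 2 (0.50 log units; beyond the scatter), where an ester-bearing side chain was replaced by the short hydroxyethyl group and the number fell from a limit to a measured value. Compound 4 carries an acid-bearing, branched chain that resembles compound 1 more than compound 2, so the step is expected to run the other way, a 2.6-fold higher number from compound 2 to compound 4 (0.41 log units; beyond the scatter). Compound 4 is therefore expected to give about 40000 nM in this assay, within 15000 nM to 120000 nM.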

Compound 4, half-maximal inhibitory concentration: 24500 nM
Compound 4: the middle estimate sits 1.6-fold (0.21 log units) above what was measured; the measured number falls inside the stated range.
By their numbers in this assay, from the lowest: compounds 2, 3 and 4 (each within the scatter of the next). At a limit, above all of these: compound 1.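

In this assay, the amide-type nitrogen carries the larger 1-carboxy-2-methylpropyl chain, with its carboxylic acid, and the numbers stay level with those of the two hydroxyl-bearing chains: a 1.6-fold higher number from compound 2 to compound 4 (0.20 log units; within the scatter), and a 1.2-fold higher number from compound 3 to compound 4 (0.07 log units; within the scatter). The earlier compounds shown here showed only hydroxyl-bearing chains with measured numbers at this position, so an acid-bearing chain is the new information. Among compounds 2, 3 and 4, neither the switch from hydroxyl to carboxylic acid nor the added branching separates the numbers.

Going by these compounds, whether an amine or a longer unbranched carboxylic acid chain would fall in the same range remains open. The step to compound 1, an at least 2.0-fold lower number from compound 1 to compound 4 (0.30 log units; that floor lies within the scatter), is also open-ended, because one end of it is a limit and not a number: the limit of > 50000 nM in this assay, at which 1 of the 4 values shown sits.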